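Fluorinated aryl ethers in the series: step to compound 4

A few compounds are considered here, and "the series" means these few. Any claim that something is new, unique, unknown or untested is made for them only; others in the source may bear on it.

The shared core is kept throughout; only the aryl ether at the far end changes. Compound 1 `CC(C)[C@H](NC(=O)COc1cccc2ccccc12)C(=O)N[C@@H](CC(=O)O)C(=O)COc1ccccc1` carries a plain phenyl there, and in a functional assay on Jurkat cells (Homo sapiens) (a lower number here means a stronger inhibitor, a higher number a weaker inhibitor), compound 1 gives 14000 nM. Compound 2 `CC(C)[C@H](NC(=O)COc1cccc2ccccc12)C(=O)N[C@@H](CC(=O)O)C(=O)COc1ccccc1C(F)(F)F` is at a limit, since in this assay compound 2 gives > 100000 nM. Compound 3 `CC(C)[C@H](NC(=O)COc1cccc2ccccc12)C(=O)N[C@@H](CC(=O)O)C(=O)COc1cc(F)ccc1F` is likewise at a limit, as in this assay compound 3 gives > 100000 nM. Compound 3 therefore stands at the weak end of the numbers shown, together with compound 2, at the limit of > 100000 nM in this assay, at which 2 of the 3 values shown sit.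

The two readable steps both run away from compound 1: an at least 7.1-fold higher number from compound 1 to compound 2 (0.85 log units; beyond the scatter), and an at least 7.1-fold higher number from compound 1 to compound 3 (0.85 log units; beyond the scatter). Between compound 2 and compound 3 the step is not readable: a step that the two limits leave unreadable from compound 2 to compound 3.

Compound 4 `CC(C)[C@H](NC(=O)COc1cccc2ccccc12)C(=O)N[C@@H](CC(=O)O)C(=O)COc1cccc(C(F)(F)F)c1F` differs from compound 3 by 2-fluoro-3-(trifluoromethyl)phenyl in place of 2,5-difluorophenyl on an oxygen on a saturated carbon. Both features that enter here, a fluorine on the ring and a trifluoromethyl, were each associated with a weakening when added to compound 1, and compound 3 already sits at the limit. No gain is expected; compound 4 is expected to remain at or beyond the limit, with a step that the limit leaves unreadable from compound 3 to compound 4 expected. For compound 4 the estimate in this assay is 150000 nM, within 50000 nM to 500000 nM.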

Compound 4, half-maximal inhibitory concentration: 50400 nM
The estimate for compound 4 lay 3.0-fold (0.47 log units) above the measured number; measured number inside the range.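

Compound 4 is the only one of the fluorinated aryl ethers shown that gives a number rather than a limit in this assay, so the position on the oxygen can carry 2-fluoro-3-(trifluoromethyl)phenyl, the larger group by heavy-atom count, with activity still readable. The plain phenyl nevertheless keeps the lower number, with a 3.6-fold higher number from compound 1 to compound 4 (0.56 log units; beyond the scatter), and so all three fluorinated groups shown go with a weaker result than compound 1. Towards the other two fluorinated compounds the steps are floors only, an at least 1.9-fold lower number from compound 3 to compound 4 (0.29 log units; that floor lies within the scatter) and an at least 1.9-fold lower number from compound 2 to compound 4 (0.29 log units; that floor lies within the scatter), and both rest on a shared limit: the limit of > 100000 nM in this assay, at which 2 of the 4 values shown sit.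

The 2-(trifluoromethyl)phenyl and 2,5-difluorophenyl groups differ from 2-fluoro-3-(trifluoromethyl)phenyl in more than one ring substituent, so the compounds shown cannot assign the readable value to either the fluorine or the trifluoromethyl alone. As far as these compounds go, whether a phenyl ring carrying a chlorine, a methoxy group or a nitrile would stay close to compound 1 or fall with the fluorinated groups also remains open.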